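Cytotoxicity notes: piperidinyl ester in place of dithiocarbamate

A few compounds are considered here, and "the series" means these few. Any claim that something is new, unique, unknown or untested is made for them only; others in the source may bear on it.

Compound 1 `Cc1ncc([N+](=O)[O-])n1CCSC(=S)N1CCC2(CC1)OCCO2` and compound 2 `Cc1ncc([N+](=O)[O-])n1CCSC(=S)N1CCC(OC(=O)CSC(=S)N2CCCC2)CC1` share a common core and have been tested in an ADME assay on HeLa cells (Homo sapiens) for cytotoxicity; a lower number here means a stronger inhibitor, a higher number a weaker inhibitor. Compound 1 gives only a limit of the assay, > 1000 ug/mL. Compound 2 likewise gives only a limit, > 1000 ug/mL. Within the data shown here, both values sit at the same assay limit (the limit of > 1000 ug/mL in this assay, at which 2 of the 2 values shown sit), so the two compounds cannot be ordered against each other, and no step between measured compounds that differ in one place is available in this pair.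

Compound 3 `Cc1ncc([N+](=O)[O-])n1CCSC(=S)N1CCC(OC(=O)CN2CCCCC2)CC1` remains to be measured. It differs from compound 2 by a group of 6 heavy atoms (5 carbon, 1 nitrogen; one six-membered non-aromatic ring with 1 hetero atom) in place of a group of 8 heavy atoms (5 carbon, 1 nitrogen, 2 sulfur; one five-membered non-aromatic ring with 1 hetero atom), on a saturated chain carbon bound to a carbonyl carbon. Among the measured compounds shown here, no measured step covers such a change. Because compound 2 reaches only the limit > 1000 ug/mL, compound 3 is expected to remain at or near that limit as well. The estimated step of a number no higher from compound 2 to compound 3 (the limit leaves the size open) is expected to be none beyond the scatter. Compound 3 is estimated at 1000 ug/mL, with a range from 400 ug/mL to 2500 ug/mL.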

Compound 3, half-maximal inhibitory concentration: 760 ug/mL
Compound 3: middle estimate off by 1.3-fold (0.12 log units), on the high side; the measured number falls inside the stated range.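

In this assay, among these compounds, compound 3 is the first compound to give a number rather than a limit, 760 ug/mL, so the end of the ester side chain is a place where a change can bring a measurable value into range. Putting piperidin-1-yl on the saturated chain carbon bound to a carbonyl carbon, in place of the sulfur-bearing group with its five-membered ring, gives an at least 1.3-fold lower number from compound 2 to compound 3 (0.11 log units; that floor lies within the scatter), and the true size of that step may be larger. Only this floor can be read, because the starting value is a limit rather than a number: the limit of > 1000 ug/mL in this assay, at which 2 of the 3 values shown sit.

The compounds shown do not separate the part played by the change from a five-membered to a six-membered ring from the part played by the loss of the two sulfur atoms, since both changes arrive together in compound 3. A morpholine ring or a dimethylamino group on the same saturated chain carbon would show whether the value of compound 3 is specific to piperidin-1-yl or holds for other amines there.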